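The source may hold more compounds than are shown below. What is called first, only, known or untested is meant among the compounds shown, and "the series" means these compounds.

Measured compounds and their values:

Compound 1, `CC(C)(C)c1ccc(CNCCCNS(=O)(=O)c2cc(C(F)(F)F)cc(C(F)(F)F)c2)cc1`, in a functional assay on BE(2)-C cells (Homo sapiens) for inhibition, read by MTT assay, with a stated time of 72 h (a lower number here means a stronger inhibitor of growth, a higher number a weaker inhibitor of growth), gives 2500 nM.
Compound 2, `O=S(=O)(NCCNCc1ccc(-c2ccccc2)cc1)c1cc(C(F)(F)F)cc(C(F)(F)F)c1`, in this assay gives 2700 nM.
Compound 3, `O=S(=O)(NCCCNCc1ccc(-c2ccccc2)cc1)c1cc(C(F)(F)F)cc(C(F)(F)F)c1`, in this assay gives 2600 nM.

The three measured compounds share a bis(trifluoromethyl)phenyl sulfonamide and a benzylamine, joined by a short chain, and their numbers in this assay sit close together. Compound 2 and compound 3 differ in their cores, and the difference between the two cores is not broken down here; what their two values show is that they are within the usual scatter of each other.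

One structural change appears twice among these compounds. From compound 3 to compound 1 it is tert-butyl in place of phenyl on an aromatic carbon, and the step it made is a 1.0-fold lower number from compound 3 to compound 1 (0.02 log units; within the scatter). The same change, at the same place, carries compound 2 to the unmeasured compound 4, `CC(C)(C)c1ccc(CNCCNS(=O)(=O)c2cc(C(F)(F)F)cc(C(F)(F)F)c2)cc1`: tert-butyl in place of phenyl on an aromatic carbon.

Because the earlier step of a 1.0-fold lower number from compound 3 to compound 1 (0.02 log units; within the scatter) stayed within the scatter, compound 4 is expected to stand close to compound 2, with an estimated step of a 1.0-fold lower number from compound 2 to compound 4 (0.02 log units; within the scatter) in this assay. On that basis, compound 4 is estimated to give about 2600 nM in this assay, most likely between 1300 nM and 5200 nM.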

Compound 4, concentration for 50% growth inhibition: 14000 nM
Compound 4: the middle estimate sits 5.4-fold (0.73 log units) below what was measured, outside the stated range (above it).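

This time, tert-butyl in place of phenyl on an aromatic carbon made a 5.2-fold higher number from compound 2 to compound 4 (0.71 log units; beyond the scatter) in this assay, so growth inhibition weakened on this core, whereas it had held steady on the other. The change therefore did not carry over with the same size from one core to the other: the same change on two cores in this assay, a 1.0-fold lower number (0.02 log units; within the scatter) from compound 3 to compound 1 and a 5.2-fold higher number (0.71 log units; beyond the scatter) from compound 2 to compound 4, 5.4-fold (0.73 log units) apart, beyond the scatter of two such steps. This shows that, for these two pairs, a step measured on one core was not a reliable guide to the step on the other, but it does not show which feature of the two cores lies behind the gap, or which of the two steps is more typical of the change across the series.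

The compounds shown leave open whether the gap between cores also appears with other groups in the same place, such as a chlorine atom, a methoxy group or a cyclohexyl ring. They also leave open whether, on a longer chain joining the sulfonamide and the amine, the same exchange of phenyl for tert-butyl would make a small step or a large one.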